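Chloro for methyl on the aryl ring: a second test

The source may report more compounds than this note shows. Statements on the series, on what has been measured and on what is new or still open speak of the compounds shown alone.

Measured compounds in an assay on LX2 cells for inhibition of COL1A1 promoter (Homo sapiens), read by a luciferase reporter, with a stated time of 24 h, tested at 50 uM; a lower number here means a weaker effect, a higher number a stronger effect of the compound at the concentration tested:
Compound 1 `Cc1cc(-n2cc(C(=O)Nc3cc(F)cc(F)c3)c(=O)c3ccc(N(C)C)nc32)ccc1OCCCCCCC[N+]12CCN(CC1)CC2` gives 20.8%.
Compound 2 `CN(C)c1ccc2c(=O)c(C(=O)Nc3cc(F)cc(F)c3)cn(-c3ccc(OCCCCCCC[N+]45CCN(CC4)CC5)c(Cl)c3)c2n1` gives 20.5%.
Compound 3 `Cc1ccc(-n2cc(C(=O)Nc3cc(F)cc(F)c3)c(=O)c3ccc(N(C)C)nc32)cc1OCCCCCCC[N+]1(C)CCCC1` gives 55.9%.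

Compound 1 and compound 2 share a core; their difference is chloro in place of methyl on an aromatic carbon, and the step of a number 0.3 percentage points lower from compound 1 to compound 2 (within the scatter) is within the scatter. Compound 3 sits highest of the three, and the difference between its core and that of compound 1 is not broken down here. Compound 4 `CN(C)c1ccc2c(=O)c(C(=O)Nc3cc(F)cc(F)c3)cn(-c3ccc(Cl)c(OCCCCCCC[N+]4(C)CCCC4)c3)c2n1` has not been measured; it differs from compound 3 by chloro in place of methyl on an aromatic carbon. Within the data shown here, this is the same kind of change as the one from compound 1 to compound 2, but not the same: here the place is para to a large group rather than meta. Because a number 0.3 percentage points lower from compound 1 to compound 2 (within the scatter) was small, a small step of a number 3.9 percentage points lower from compound 3 to compound 4 (within the scatter) is expected here too, though the different surroundings add uncertainty. Compound 4 is therefore estimated at 52%, between 35% and 66%.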

Compound 4, a percentage reported as inhibition, at one concentration (the size of the read-out at that concentration, not a potency): 76.1%
Estimate against measurement, compound 4: 24.1 percentage points below; measured number outside the range, above it.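

Chloro in place of methyl on an aromatic carbon gives a number 20.2 percentage points higher from compound 3 to compound 4 (beyond the scatter) in this assay. The change therefore does not carry over with the same size from one core to the other: the same change on two cores in this assay, a number 0.3 percentage points lower (within the scatter) from compound 1 to compound 2 and a number 20.2 percentage points higher (beyond the scatter) from compound 3 to compound 4, 20.5 percentage points apart, beyond the scatter of two such steps

This shows that a step measured on one core cannot simply be copied to another core in this series, but it does not show which difference between the cores matters, and two pairs give no general rule. The compounds shown leave open whether fluoro, bromo or methoxy on the same aromatic carbon would behave like chloro. They also leave open whether a shorter or longer chain would alter the step.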